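The source may report more compounds than this note shows. Statements on the series, on what has been measured and on what is new or still open speak of the compounds shown alone.

Measured compounds:
compound 1 `CNC(=O)C#Cc1ccc(NC(=O)Nc2ccc(Cl)c(C(F)(F)F)c2)cc1`: 24700 nM
compound 2 `O=C(CCc1ccc(NC(=O)Nc2ccc(Cl)c(C(F)(F)F)c2)cc1)NC1CCC1`: > 50000 nM, a limit
compound 3 `O=C(/C=C/c1ccc(NC(=O)Nc2ccc(Cl)c(C(F)(F)F)c2)cc1)NC1CCC1`: 17300 nM

In a functional assay on KETR3 cells (Homo sapiens) for inhibition, read by MTT assay, with a stated time of 120 h (a higher number here means a weaker inhibitor, a lower number a stronger inhibitor), compound 3 gives 17300 nM, the lowest of the two numbers. Its nearest neighbour is compound 1, and a 1.4-fold lower number from compound 1 to compound 3 (0.15 log units; within the scatter). Compound 2 sits at the limit of > 50000 nM in this assay, at which 1 of the 3 values shown sits, so only a limit is known for it; an at least 2.8-fold lower number from compound 2 to compound 3 (0.46 log units; beyond the scatter).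

Compound 4 `CNC(=O)c1cccc(-c2ccc(NC(=O)Nc3ccc(Cl)c(C(F)(F)F)c3)cc2)c1` is to be measured. It differs from compound 3 as 3-(methylcarbamoyl)phenyl in place of 2-(cyclobutylcarbamoyl)ethenyl on an aromatic carbon. The step from compound 2 to compound 3 shows that the rigid ethenyl linker gives a lower number than the saturated ethyl one; the step from compound 1 to compound 3 shows that swapping methylcarbamoyl for cyclobutylcarbamoyl on a rigid linker stays within the scatter. Compound 4 keeps a rigid link, now an aromatic ring, and returns to methylcarbamoyl as in compound 1. Going by the values given here, no measured step covers an aromatic linker, so the expectation is a step within the scatter, a 1.2-fold higher number from compound 3 to compound 4 (0.06 log units; within the scatter). For compound 4 the estimated value is 20000 nM, with a range from 8000 nM to 50000 nM.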

Compound 4, half-maximal inhibitory concentration: 39300 nM
Beside the measured number, compound 4's estimate is 2.0-fold (0.29 log units) below it; measured number inside the range.
By their numbers in this assay, from the lowest: compounds 3, 1 and 4 (each within the scatter of the next, the first and the last beyond it). At a limit, above all of these: compound 2.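

In this assay, this aromatic carbon, para to a large group, accepts 3-(methylcarbamoyl)phenyl less well than 2-(cyclobutylcarbamoyl)ethenyl: a 2.3-fold higher number from compound 3 to compound 4 (0.36 log units; beyond the scatter). The same group cannot be separated from 2-(methylcarbamoyl)ethynyl: a 1.6-fold higher number from compound 1 to compound 4 (0.20 log units; within the scatter). So 3-(methylcarbamoyl)phenyl gives no gain over either of these groups here, and among compound 1, compound 3 and compound 4 only compound 3 and compound 4 are separated. The value for compound 2 is a limit: the limit of > 50000 nM in this assay, at which 1 of the 4 values shown sits. The step that follows from it is a floor only: an at least 1.2-fold lower number from compound 2 to compound 4 (0.10 log units; that floor lies within the scatter).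

The change from compound 3 to compound 4 alters both the link and the amide substituent, so the share of each remains unresolved. Also open, on these data alone, is whether a carboxylic acid or an amine in place of the amide would give a lower number at this position.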